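This account rests on a few compounds, and the source may have more. Where it says the series, first, only, none or still open, it means among the compounds named here.

Measured so far:
compound 1, `COc1ccccc1NC(=O)Nc1nc2ccc(F)cc2s1`: > 10 ug/mL
compound 2, `Cc1ccc(C(=O)Nc2nc3cc(C)cc(C)c3s2)cc1`: 2.17 ug/mL

In a functional assay on SK-HEP1 cells (Homo sapiens) for antiproliferative activity, read by sulforhodamine B assay (a lower number here means a stronger inhibitor of growth, a higher number a weaker inhibitor of growth), compound 1 gives > 10 ug/mL, which is a limit of the assay and not a number. Compound 1 therefore stands at the limit of > 10 ug/mL in this assay, at which 1 of the 2 values shown sits. Compound 2, with its own amide-linked core, gives 2.17 ug/mL in this assay, a measured number. Among the compounds with values here, no step between compound 1 and compound 2 is given, so the two values can only be set side by side.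

Compound 3, `O=C(Nc1nc2ccc(F)cc2s1)Nc1ccccc1F`, is not yet measured. It differs from compound 1 by fluoro in place of methoxy on an aromatic carbon, ortho to a large group on the six-membered aromatic ring. Within the data shown here, with no measured step to lean on, the change from compound 1 is expected to give a step of none beyond the scatter in this assay. For compound 3 the estimated step that the limit leaves unreadable from compound 1 to compound 3 is expected to stay small. Compound 3 is expected at 12 ug/mL, within a range from 4 ug/mL to 30 ug/mL, most likely again reported only as a limit.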

Compound 3, concentration for 50% growth inhibition: > 10 ug/mL
Compound 3 gave a limit, no number (the forecaster's own chance of this, stated with the estimate: 70%); the middle value does not contradict the limit.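

Compound 1 and compound 3 both give only a limit of the assay and not a number, and no step can be read between them. The compounds shown leave open whether fluoro in place of methoxy on an aromatic carbon makes any difference in this assay.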